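Ester aryl swap: from 3-chlorophenyl to 4-methoxyphenyl

A few compounds are considered here, and "the series" means these few. Any claim that something is new, unique, unknown or untested is made for them only; others in the source may bear on it.

Two esters of the shared core have been measured in a functional assay on MCF7 cells (Homo sapiens) for antiproliferative activity, read by sulforhodamine B assay, with a stated time of 48 h, tested at 50 uM; a higher number here means more inhibition at the concentration tested (going by the name of the read-out), a lower number less inhibition. Compound 1 `CC1=CC[C@H](C(C)C)c2cc(C)c(OC(=O)c3ccc([N+](=O)[O-])cc3)cc21` gives 72.9%. Compound 2 `CC1=CC[C@H](C(C)C)c2cc(C)c(OC(=O)c3cccc(Cl)c3)cc21` gives 40.4%, the lowest of the two numbers; its nearest neighbour is compound 1, and the step of a number 32.5 percentage points lower from compound 1 to compound 2 (beyond the scatter) shows that exchanging the aryl group on the carbonyl carbon alone can move the read-out by a large amount.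

The next compound, compound 3 `COc1ccc(C(=O)Oc2cc3c(cc2C)[C@@H](C(C)C)CC=C3C)cc1`, changes the same place: 4-methoxyphenyl in place of 3-chlorophenyl on a carbonyl carbon. Among the measured compounds shown here, no measured step covers this particular exchange, so the only guidance is the size of the one step that is known. That step was large and downward; the new group shares nothing with either of the two measured aryl groups beyond the ring, so its direction cannot be read from the data.

For the measured compounds named here, the expectation for compound 3 is therefore wide and centred a little above compound 2, with a step of a number 4.6 percentage points higher from compound 2 to compound 3 (within the scatter) expected, because the one known step of a number 32.5 percentage points lower from compound 1 to compound 2 (beyond the scatter) was large and because compound 2 gives 40.4%, which leaves more room upward. Compound 3 is estimated at 45%, with a range from 20% to 75%.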

Compound 3, a percentage reported as inhibition, at one concentration (the size of the read-out at that concentration, not a potency): 80.1%
Compound 3: middle estimate off by 35.1 percentage points, on the low side, outside the stated range (above it).
By their numbers in this assay, from the lowest: compound 2; then compounds 1 and 3 (each within the scatter of the next).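

In this assay the step of a number 39.7 percentage points higher from compound 2 to compound 3 (beyond the scatter) shows that the aryl group on this carbonyl carbon can move the read-out by a large amount upward as well as downward, so the three esters now fall into compound 2 on one side and compounds 1 and 3 on the other. The step of a number 7.2 percentage points higher from compound 1 to compound 3 (within the scatter) shows that methoxy in place of nitro on an aromatic carbon is not resolved at this single concentration, so 4-methoxyphenyl and 4-nitrophenyl cannot be told apart here, although their names share little beyond the ring. Nothing measured on these groups bears on this result, so the data offer no explanation for it.

From the compounds shown here alone, whether the lower number of compound 2 goes with chlorine itself or with the 3-chlorophenyl arrangement stays open, and a 4-chlorophenyl ester would separate the two. Going by these compounds, it also remains open whether the high numbers extend to other groups on the ring, such as an amine or a carboxylic acid, and a read-out at one concentration gives no potency for compounds 1 and 3.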